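The source may hold more compounds than are shown below. What is called first, only, known or untested is meant among the compounds shown, and "the series" means these compounds.

Measured compounds: `O=C(NCc1cccnc1)Nc1ccc(CN2C(=O)c3ccccc3C2=O)cc1` is compound 1; in an assay on isolated protein for inhibition of Nicotinamide phosphoribosyltransferase (Homo sapiens), read by mass spectrometry, with stated times of 15 min and 90 min (a lower number here means a stronger inhibitor, a higher number a weaker inhibitor), compound 1 gives 3.1 nM. `O=C(Nc1ccc(CN2C(=O)c3ccccc3C2=O)cc1)[C@H]1C[C@@H]1c1cccnc1` is compound 2. In this assay compound 2 reaches only a limit, < 1 nM, so its true number is not known (the limit of < 1 nM in this assay, at which 1 of the 2 values shown sits).

Compound 2 therefore stands at the strong end of the two measured compounds: the step of an at least 3.1-fold lower number from compound 1 to compound 2 (0.49 log units; beyond the scatter) is beyond the scatter, though its full size is hidden by the limit.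

Compound 3, `O=C(Nc1ccc(CN2C(=O)c3ccccc3C2=O)cc1)[C@@H]1C[C@H]1c1cccnc1`, is the unmeasured partner of compound 2. Compared with compound 2: the two compounds have the same atoms and bonds and differ only in configuration as drawn: 2 of 2 stereo elements differ (all stereocentres are inverted: mirror images); a stereocentre at a saturated ring carbon is drawn S in compound 2 and R in compound 3; a stereocentre at a saturated ring carbon is drawn S in compound 2 and R in compound 3. Going by the values given here, only one step has been measured, and it concerns the group on the carbonyl carbon, not configuration; no measured step bears on an inversion of both stereocentres. The expected size and direction of the step for compound 3 in this assay is thus open, and the estimated step of an at least 20-fold higher number from compound 2 to compound 3 (1.30 log units; beyond the scatter) carries a wide range. Compound 3 is expected to give around 20 nM in this assay, with a range from 1 nM to 500 nM.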

Compound 3, half-maximal inhibitory concentration: > 2500 nM
Compound 3 ended at the assay's limit; the forecaster's own chance of this, stated with the estimate: 20%; middle value at least 120-fold (2.09 log units) away from the limit.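

Inverting both stereocentres of the 2-(pyridin-3-yl)cyclopropyl group gives an at least 2500-fold higher number from compound 2 to compound 3 (3.39 log units; beyond the scatter) in this assay, and this step comes from configuration alone: the fact that compounds 2 and 3 differ only in the configuration as drawn. Compound 3 stands at a limit of the assay: the limit of > 2500 nM in this assay, at which 1 of the 3 values shown sits. The gain from this group over ((pyridin-3-yl)methyl)amino on the carbonyl carbon therefore holds for one drawn configuration only, as an at least 3.1-fold lower number from compound 1 to compound 2 (0.49 log units; beyond the scatter) contrasts with an at least 800-fold higher number from compound 1 to compound 3 (2.90 log units; beyond the scatter).

It remains open how much each stereocentre contributes, since the only configurational pair shown has both inverted, and the true size of the step stays hidden by the limit on compound 2. Also open, as far as these compounds go, is whether this dependence on configuration would persist with a cyclobutyl ring in place of the cyclopropyl ring, or with phenyl in place of pyridin-3-yl.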